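Iodo in place of bromo: compound 3 to compound 4

The source may report more compounds than this note shows. Statements on the series, on what has been measured and on what is new or still open speak of the compounds shown alone.

In a functional assay on DU-145 cells (Homo sapiens) for inhibition, read by trypan blue exclusion, with a stated time of 96 h (a higher number here means a weaker inhibitor of growth, a lower number a stronger inhibitor of growth), compound 1 (`O=C(/C(=C/c1ccc(Br)cc1)S(=O)(=O)Cc1ccc(I)cc1)c1ccc(I)cc1`) gives 20000 nM and compound 3 (`O=C(/C(=C/c1ccc(I)cc1)S(=O)(=O)Cc1ccc(I)cc1)c1ccc(Br)cc1`) gives 20000 nM as well. These two are level, within the scatter, and share the highest of the three numbers. Compound 2 (`Cc1ccc(CS(=O)(=O)/C(=C/c2cccc(Cl)c2Cl)C(=O)c2ccc(Cl)cc2)cc1`) reads 1000 nM and sits well below compound 3, beyond the scatter, though it differs from compound 3 in several places.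

Compound 4 (`O=C(/C(=C/c1ccc(I)cc1)S(=O)(=O)Cc1ccc(I)cc1)c1ccc(I)cc1`) is the next to be read. The change is iodo in place of bromo on an aromatic carbon with iodo in place of bromo on an aromatic carbon, para to a large group.

Going by the values given here, no measured pair differs in one place, so direct guidance is missing. Compound 1 and compound 3 each carry one bromo and two iodo groups, placed differently, and compound 1 at 20000 nM shows no separation from compound 3. The expected step of no change at the digits printed from compound 3 to compound 4 (within the scatter) in this assay is none beyond the scatter. For compound 4 the estimated value is 20000 nM with an expected range of 8000 nM to 50000 nM as the working estimate.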

Compound 4, concentration for 50% growth inhibition: 50000 nM
Compound 4: the middle estimate sits 2.5-fold (0.40 log units) below what was measured; measured number inside the range.
By their numbers in this assay, from the lowest: compound 2; then compounds 1 and 3 (each within the scatter of the next); then compound 4.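

In this assay, going by these compounds alone, the change from 4-bromophenyl to 4-iodophenyl on the carbonyl gives a 2.5-fold higher number from compound 3 to compound 4 (0.40 log units; beyond the scatter) and is the first single-place step. The same exchange of iodo for bromo at the bromo-bearing aromatic carbon of compound 1 gives a 2.5-fold higher number from compound 1 to compound 4 (0.40 log units; beyond the scatter), so both single exchanges run the same way and at the same size, a separation that the level values of the two bromo compounds did not reveal. Nothing measured in this set gives a reason for either step.

On these data alone, whether a methoxy group or an amine at either of these places would move the number in this assay stays open. Compound 2 at 1000 nM differs from these compounds in several places, so its lower number cannot be tied to any single group.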